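This account rests on a few compounds, and the source may have more. Where it says the series, first, only, none or still open, it means among the compounds named here.

Measured so far in an assay on microsomes from liver for inhibition of 3-hydroxy-3-methylglutaryl-coenzyme A reductase (Rattus norvegicus); on this read-out higher numbers stand for weaker inhibition and lower numbers for stronger inhibition:
Compound 1, `O=C(O)C[C@H](O)C[C@H](O)CCn1c(C(F)(F)F)nc(-c2ccccc2)c1-c1ccc(F)cc1`, gives 31 nM.
Compound 2, `COc1cccc(-c2nc(C(F)(F)F)n(CC[C@@H](O)C[C@@H](O)CC(=O)O)c2-c2ccc(F)cc2)c1`, gives 20 nM.
Compound 3, `O=C(O)C[C@H](O)C[C@H](O)CCn1c(C(F)(F)F)nc(-c2ccc(C(F)(F)F)cc2)c1-c1ccc(F)cc1`, gives 200 nM.

Among these three, compound 3 carries the highest number, which on this read-out means the weakest inhibition; the steps of a 6.5-fold higher number from compound 1 to compound 3 (0.81 log units; beyond the scatter) and a 10-fold higher number from compound 2 to compound 3 (1.00 log units; beyond the scatter) both lie beyond the scatter. Compound 4, `Cc1cc(-c2nc(C(F)(F)F)n(CC[C@@H](O)C[C@@H](O)CC(=O)O)c2-c2ccc(F)cc2)cc(C)c1F`, has not yet been measured in this assay. It differs from compound 3 in one place: 4-fluoro-3,5-dimethylphenyl in place of 4-(trifluoromethyl)phenyl on an aromatic carbon. Among the measured compounds shown here, two measured steps bear on this change, since each of them introduced the trifluoromethyl on an aromatic carbon that compound 4 no longer carries: a 6.5-fold higher number from compound 1 to compound 3 (0.81 log units; beyond the scatter) and a 10-fold higher number from compound 2 to compound 3 (1.00 log units; beyond the scatter). Read in reverse, they suggest that the number should come back down toward those of compound 1 and compound 2. For the measured compounds named here, no measured step tells what the entering fluoro and two methyls contribute, so the range has to stay wide. The expected step is a 5.0-fold lower number from compound 3 to compound 4 (0.70 log units; beyond the scatter). Compound 4 is therefore estimated at 40 nM, between 10 nM and 200 nM.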

Compound 4, half-maximal inhibitory concentration: 32 nM
Compound 4: the middle estimate sits 1.3-fold (0.10 log units) above what was measured, within the range that was stated.
By their numbers in this assay, from the lowest: compounds 2, 1 and 4 (each within the scatter of the next); then compound 3.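

This position on the shared core tolerates more than a plain phenyl: replacing 4-(trifluoromethyl)phenyl with 4-fluoro-3,5-dimethylphenyl gives a 6.3-fold lower number from compound 3 to compound 4 (0.80 log units; beyond the scatter), and the new group sits level with phenyl, at a 1.0-fold higher number from compound 1 to compound 4 (0.01 log units; within the scatter), and with 3-methoxyphenyl, at a 1.6-fold higher number from compound 2 to compound 4 (0.20 log units; within the scatter), both steps being within the scatter. Adding groups to this phenyl ring therefore does not by itself raise the number, and among the four compounds only compound 3, with its trifluoromethyl, goes against that reading. Nothing available explains why the trifluoromethyl stands apart from the fluoro and two methyls.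

The compounds shown leave open what the fluoro and the two methyls each contribute when present alone. They also leave open how this position would respond to a ring carrying an amine or a carboxylic acid.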